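Replacing the Pyridinyl-Imidazole Arm of Compound 2 with Furan

A few compounds are considered here, and "the series" means these few. Any claim that something is new, unique, unknown or untested is made for them only; others in the source may bear on it.

In a functional assay on SK-BR-3 cells (Homo sapiens) for inhibition, read by CellTiter-Glo, with a stated time of 72 h (a higher number here means a weaker inhibitor, a lower number a stronger inhibitor), compound 2 `CC(C)c1nn(-c2ccc(C(N)=O)c(N[C@H]3CC[C@H](O)CC3)c2)c2nccc(-n3cnc(-c4ccncc4)c3)c12` gives 165 nM, the lowest of the three numbers recorded. Compound 1 `CNc1cc(C(N)=O)ccc1-n1nc(C(C)C)c2c(-n3cnc(-c4cnn(C)c4)c3)ccnc21` gives 419 nM, and compound 3 `CC(C)c1nn(-c2ccc(C(N)=O)c(N[C@H]3CC[C@H](O)CC3)c2)c2nccc(-n3cnc(-c4ccc(Oc5ccccc5)cc4)c3)c12` gives 503 nM; both gaps to compound 2 lie beyond the usual scatter of such measurements. Compound 4 `CC(C)c1nn(-c2ccc(C(N)=O)c(N[C@H]3CC[C@H](O)CC3)c2)c2nccc(-c3ccoc3)c12` differs from compound 2 by furan-3-yl in place of 4-(pyridin-4-yl)-1H-imidazol-1-yl on an aromatic carbon. Among the compounds with values here, no measured pair shows this exact exchange, so the expectation rests on the three numbers alone. Because compound 2 carries the larger group and gives 165 nM, the smaller furan-3-yl is expected to weaken inhibition. The estimated step is a 5.5-fold higher number from compound 2 to compound 4 (0.74 log units; beyond the scatter). Compound 4 is therefore expected near 900 nM, within a range of 250 nM to 3500 nM.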

Compound 4, half-maximal inhibitory concentration: > 10000 nM
Compound 4 ended at the assay's limit; the forecaster's own chance of this, stated with the estimate: 10%; middle value at least 11-fold (1.04 log units) away from the limit.
By their numbers in this assay, from the lowest: compound 2; then compounds 1 and 3 (each within the scatter of the next). At a limit, above all of these: compound 4.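

In this assay, furan-3-yl in place of 4-(pyridin-4-yl)-1H-imidazol-1-yl on this aromatic carbon gives an at least 60-fold higher number from compound 2 to compound 4 (1.78 log units; beyond the scatter), so the group here cannot be exchanged freely. The value of compound 4 is a limit of the assay, not a number: the limit of > 10000 nM in this assay, at which 1 of the 4 values shown sits. Compound 1, compound 2 and compound 3 all carry a substituted imidazole here, and compound 4 alone lacks it.

As far as these compounds go, the change removes both rings at once, and which of them matters stays open. An unsubstituted 1H-imidazol-1-yl or a lone pyridin-4-yl on this carbon would separate the two.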